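A few compounds are considered here, and "the series" means these few. Any claim that something is new, unique, unknown or untested is made for them only; others in the source may bear on it.

Series notes. Compound 1 `Cc1cc(C(=O)Nc2cc(CC(=O)O)ccc2Cl)c(C)cc1OC[C@@H]1CN(C)c2ccccc2O1` is measured in an assay on CHO cells for displacement of a labelled ligand from prostacyclin receptor (Homo sapiens), read by scintillation counting, with a stated time of 30 min (a higher number here means a weaker inhibitor, a lower number a stronger inhibitor), where compound 1 gives 1800 nM. Compound 3 `Cc1cc(C(=O)Nc2cc(C(C)(C)C(=O)O)ccc2Cl)c(C)cc1OC[C@@H]1CN(C)c2ccccc2O1` carries the change 1-carboxy-1-methylethyl in place of carboxymethyl on an aromatic carbon on the core of compound 1; in this assay compound 3 gives 3300 nM. The step of a 1.8-fold higher number from compound 1 to compound 3 (0.26 log units; within the scatter) is accordingly small.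

Compound 2 `Cc1cc(OC[C@@H]2CN(C)c3ccccc3O2)cc(C)c1C(=O)Nc1cc(CC(=O)O)ccc1Cl` has the same atoms as compound 1, joined differently; the difference between the two cores is not broken down here. In this assay compound 2 gives > 10000 nM, which is a limit of the assay and not a number, namely (the limit of > 10000 nM in this assay, at which 1 of the 3 values shown sits).

Compound 4 `Cc1cc(OC[C@@H]2CN(C)c3ccccc3O2)cc(C)c1C(=O)Nc1cc(C(C)(C)C(=O)O)ccc1Cl` is not yet measured. It stands to compound 2 as compound 3 stands to compound 1: the change 1-carboxy-1-methylethyl in place of carboxymethyl on an aromatic carbon is the same change, on the core of compound 2 instead. Among the four compounds this change occurs twice, once measured and once pending.

The expectation for compound 4 rests on two things: the measured pair, whose step a 1.8-fold higher number from compound 1 to compound 3 (0.26 log units; within the scatter) lies within the scatter, and compound 2 already sitting at a limit in this assay. For compound 4 the expected step is a step that the limit leaves unreadable from compound 2 to compound 4, of the same order as the measured one. Compound 4 is therefore estimated at 15000 nM, with a range from 7000 nM to 40000 nM, and the most likely outcome is that this assay again reports only a limit for compound 4 rather than a number.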

Compound 4, inhibition constant in the prostacyclin receptor assay: > 10000 nM
Compound 4: a limit, no number (the forecaster's own chance of this, stated with the estimate: 80%); the middle value does not contradict the limit.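

In the prostacyclin receptor assay compound 4 gives > 10000 nM, which is a limit and not a number. In the prostacyclin receptor assay compound 2 gives > 10000 nM, which is also a limit and not a number. No step between compound 2 and compound 4 can be read, because both sit at the same limit: the limit of > 10000 nM in the prostacyclin receptor assay, at which 2 of the 4 values shown sit.

The compounds shown leave open whether 1-carboxy-1-methylethyl in place of carboxymethyl changes the result in the prostacyclin receptor assay at all on the core of compound 2.

In a physicochemical assay for solubility, measured as kinetic solubility (on this read-out higher numbers stand for higher solubility and lower numbers for lower solubility), compound 2 gives 407 ug/mL and compound 4 gives 490 ug/mL. In the physicochemical assay this is a 1.2-fold higher number from compound 2 to compound 4 (0.08 log units; within the scatter), so these two values stand within the scatter of each other.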